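Anilide aryl swap on the tetrahydroisoquinoline-carboxamide series

This account rests on a few compounds, and the source may have more. Where it says the series, first, only, none or still open, it means among the compounds named here.

Measured so far:
compound 1 `COc1ccc(NC(=O)C2c3ccccc3CCN2C(=O)c2ccc(Cl)cc2)cc1` — 3630 nM
compound 2 `O=C(Nc1ccc(Cl)cc1)c1nccc2ccccc12` — > 10000 nM
compound 3 `COc1ccc(NC(=O)C2NCCc3ccccc32)cc1` — > 10000 nM

Within the data shown here, in a functional assay on NUGC-3 cells (Homo sapiens) for inhibition, read by sulforhodamine B assay, with a stated time of 48 h (a lower number here means a stronger inhibitor of growth, a higher number a weaker inhibitor of growth), compound 1 gives 3630 nM, the only number among the three. For compound 2 the result is a limit, > 10000 nM. For compound 3 the result is likewise a limit, > 10000 nM. Among the measured compounds shown here, the one step that can be sized runs an at least 2.7-fold higher number from compound 1 to compound 3 (0.44 log units; beyond the scatter), so the (4-chlorophenyl)carbonyl on the ring nitrogen matters to growth inhibition, with the size bounded only from below because of the limit of > 10000 nM in this assay, at which 2 of the 3 values shown sit.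

Compound 4 `O=C(Nc1ccccc1C(F)(F)F)C1c2ccccc2CCN1C(=O)c1ccc(Cl)cc1` keeps that acyl group and alters the other end: 2-(trifluoromethyl)phenyl in place of 4-methoxyphenyl on an amide-type nitrogen. For the measured compounds named here, no measured pair touches this anilide aryl, so no step bears directly on it; the change is of a different kind from the one in the step from compound 1 to compound 3. The expectation for this assay is therefore a step of no clear direction, within or near the scatter, a 1.2-fold higher number from compound 1 to compound 4 (0.09 log units; within the scatter). Compound 4 is estimated at 4500 nM, with a range from 1500 nM to 14000 nM.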

Compound 4, concentration for 50% growth inhibition: > 10000 nM
Compound 4 gave a limit, no number; the forecaster's own chance of this, stated with the estimate: 35%; at least 2.2-fold (0.34 log units) between middle value and limit.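

With the (4-chlorophenyl)carbonyl held fixed, 2-(trifluoromethyl)phenyl in place of 4-methoxyphenyl on the amide-type nitrogen gives an at least 2.7-fold higher number from compound 1 to compound 4 (0.44 log units; beyond the scatter) in this assay, so growth inhibition depends on this aryl as well as on the acyl group. The reading for compound 4 is a limit, and the full size of the step stays unknown because of that limit: the limit of > 10000 nM in this assay, at which 3 of the 4 values shown sit. Both single changes from compound 1 shown so far, at the ring nitrogen and at the anilide aryl, end at this limit.

The swap alters both the substituent and its printed ring position, and a 2-methoxyphenyl or a 4-(trifluoromethyl)phenyl would separate the two. As far as these compounds go, whether any other aryl on this nitrogen, such as 4-ethoxyphenyl, gives a lower number than compound 1 at 3630 nM also remains open.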